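A Trifluoromethyl for Methoxy Swap at the Potency Limit

A few compounds are considered here, and "the series" means these few. Any claim that something is new, unique, unknown or untested is made for them only; others in the source may bear on it.

Compound 1 `CCOC(=O)C1=Cc2ccccc2OC1(OCc1cn(-c2cccc(OC)c2)nn1)C(F)(F)F` was examined in a functional assay on HeLa cells (Homo sapiens) for inhibition, read by MTT assay, with a stated time of 24 h; a higher number here means a weaker inhibitor, a lower number a stronger inhibitor; there compound 1 gives > 150000 nM, which is a limit of the assay rather than a number. Compound 2 `CCOC(=O)C1=Cc2ccccc2OC1(OCc1cc(-c2ccc([N+](=O)[O-])cc2)no1)C(F)(F)F` also returns only a limit, > 150000 nM. Compound 3 `O=C(O)C1=Cc2ccccc2OC1(OCc1cc(-c2ccc(F)cc2)no1)C(F)(F)F` likewise sits at a limit, > 150000 nM. Compound 1 therefore stands exactly where its two companions do, at the limit of > 150000 nM in this assay, at which 3 of the 3 values shown sit. Compound 4 `CCOC(=O)C1=Cc2ccccc2OC1(OCc1cn(-c2cccc(C(F)(F)F)c2)nn1)C(F)(F)F` differs from compound 1 by trifluoromethyl in place of methoxy on an aromatic carbon. Among the compounds with values here, no step between measured compounds is available, so the change is expected to move the value little, if at all, beyond the scatter. The step of a number no higher from compound 1 to compound 4 (the limit leaves the size open) is expected to be essentially flat. Compound 4 is estimated to give about 150000 nM in this assay, between 50000 nM and 500000 nM, most probably again as a limit.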

Compound 4, half-maximal inhibitory concentration: > 150000 nM
Compound 4: no number, only a limit; the forecaster's own chance of this, stated with the estimate: 85%; the middle value sits exactly at the limit.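

Compound 1 and compound 4 each return only a limit in this assay, so no step between them can be read: the limit of > 150000 nM in this assay, at which 4 of the 4 values shown sit.

The compounds shown leave open how strong any of them actually is, and whether trifluoromethyl in place of methoxy changes inhibition at all.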